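Replacing the lactam with an oxazole: expected half-life

The source may report more compounds than this note shows. Statements on the series, on what has been measured and on what is new or still open speak of the compounds shown alone.

The series shares one core with a variable group on a saturated chain carbon bound to an aromatic carbon and a saturated chain carbon. Compound 1 `CC(C)C(c1nnc[nH]1)c1ccc(-c2ccc3cccc(F)c3c2)[nH]c1=O` carries 4H-1,2,4-triazol-3-yl there and in an ADME assay on microsomes from liver (Mus musculus) for metabolic stability (a lower number here means that the compound disappears faster, a higher number that the compound lasts longer), compound 1 gives 0.213 h. Compound 2 `CC(C)C(c1ccc(-c2ccc3cccc(F)c3c2)[nH]c1=O)N1CCCCC1=O` carries 2-oxopiperidin-1-yl and in this assay compound 2 gives 0.0967 h, the second highest of the three numbers. Compound 3 `CC(C)C(Nc1nccs1)c1ccc(-c2ccc3cccc(F)c3c2)[nH]c1=O` carries (1,3-thiazol-2-yl)amino and in this assay compound 3 gives 0.0733 h. The steps show a 2.2-fold lower number from compound 1 to compound 2 (0.34 log units; beyond the scatter), a 2.9-fold lower number from compound 1 to compound 3 (0.46 log units; beyond the scatter) and a 1.3-fold lower number from compound 2 to compound 3 (0.12 log units; within the scatter).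

Compound 4 `CC(C)C(c1ncco1)c1ccc(-c2ccc3cccc(F)c3c2)[nH]c1=O` differs from compound 2 in one place: 1,3-oxazol-2-yl in place of 2-oxopiperidin-1-yl on a saturated chain carbon bound to an aromatic carbon and a saturated chain carbon. The step from compound 1 to compound 2 bears most on it, since compound 4, like compound 1, carries a five-membered aromatic ring with two hetero atoms there, so a modest rise is expected, though possibly within the scatter. Compound 4 is therefore expected to give 0.15 h in this assay, with a range from 0.07 h to 0.32 h. This estimate means a 1.6-fold higher number from compound 2 to compound 4 (0.19 log units; within the scatter).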

Compound 4, half-life: 0.08 h
For compound 4 the middle estimate is 1.9-fold (0.27 log units) above the measured one; the range from low to high includes it.
By their numbers in this assay, from the lowest: compounds 3, 4 and 2 (each within the scatter of the next); then compound 1.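

In this assay, the 1,3-oxazol-2-yl group does not separate from the two non-aromatic-linked groups already tested at this place, with a 1.2-fold lower number from compound 2 to compound 4 (0.08 log units; within the scatter) and a 1.1-fold higher number from compound 3 to compound 4 (0.04 log units; within the scatter) as the two steps that show it. Compound 1 alone stands apart, with a 2.7-fold lower number from compound 1 to compound 4 (0.43 log units; beyond the scatter), so carrying a five-membered aromatic ring at this place is not enough to give the number of compound 1. Nothing at hand accounts for the gap between the 4H-1,2,4-triazol-3-yl group and the 1,3-oxazol-2-yl group.

Going by these compounds, it remains open whether another five-membered ring here, such as an imidazole or a tetrazole, would match compound 1. On these data alone, how a carboxylic acid or an amine at this place would compare also remains open.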